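A few compounds are considered here, and "the series" means these few. Any claim that something is new, unique, unknown or untested is made for them only; others in the source may bear on it.

Series notes. In a functional assay on MCF7 cells (Homo sapiens) for inhibition, read by MTT assay, with a stated time of 72 h (on this read-out higher numbers stand for weaker inhibition and lower numbers for stronger inhibition), compound 3 `CCCCCC(=O)N1CCN(c2nnc3nncn3n2)CC1` gives 5260 nM, the highest of the two numbers recorded so far; compound 1 `c1nnc2nnc(N3CCCC3)nn12`, the nearest neighbour, gives 5130 nM, which lies within the scatter of compound 3. For compound 2 `OCC(CO)(CO)Nc1nnc2nncn2n1` this assay reports only a limit, > 100000 nM, and no number, so it offers no anchor (the limit of > 100000 nM in this assay, at which 1 of the 3 values shown sits). The shared core of compound 3 is kept in compound 4 `CCCCC(=O)N1CCN(c2nnc3nncn3n2)CC1`, which differs by hydrogen in place of methyl on a saturated chain carbon, four bonds along the chain from a carbonyl carbon. For the measured compounds named here, no measured pair in the set reports a comparable step, so the direction is open; the expectation is that the step from compound 3 to compound 4 stays within the scatter, with no change beyond it. Compound 4 is therefore estimated at 5500 nM in this assay, expected range 2500 nM to 12000 nM, meaning a step of a 1.0-fold higher number from compound 3 to compound 4 (0.02 log units; within the scatter).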

Compound 4, half-maximal inhibitory concentration: 2760 nM
Compound 4: the middle estimate sits 2.0-fold (0.30 log units) above what was measured; measured number inside the range.
By their numbers in this assay, from the lowest: compounds 4, 1 and 3 (each within the scatter of the next). At a limit, above all of these: compound 2.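

For the compounds shown here, the step at this place, hydrogen in place of methyl on a saturated chain carbon, four bonds along the chain from a carbonyl carbon, is the first to be read between two measured compounds: in this assay it is a 1.9-fold lower number from compound 3 to compound 4 (0.28 log units; within the scatter). The chain therefore takes this single-carbon change without a shift beyond the scatter. No measured property shown bears on this step.

As far as these compounds go, whether a much shorter chain, a longer chain, or an amine or carboxylic acid at the chain end would move the number beyond the scatter stays open. A single step gives no trend along the chain.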